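From propoxy to cyclopentylsulfanyl: a step against a limit

The compounds below may be only part of what the source reports. "The series", "measured", "known", "first", "only" and "open" are said of these compounds alone.

Values so far in an ADME assay on MOLT-3 cells (Homo sapiens) for cytotoxicity, with a stated time of 7 days (a higher number here means that more compound is tolerated, a lower number that less compound is tolerated), are these:

Compound 1 `CC(C)CSc1nc(N)nc2c1ncn2/C=C1/CC1(CO)CO` gives "not determined" (no result reported)
Compound 2 `CCOc1nc(N)nc2c1ncn2/C=C1/CC1(CO)CO` gives > 20000 nM as a limit
Compound 3 `CCCOc1nc(N)nc2c1ncn2/C=C1/CC1(CO)CO` gives > 20000 nM as a limit

Compound 3 stands at > 20000 nM as a limit and not a number. Compound 2 and compound 3 share the limit of > 20000 nM in this assay, at which 2 of the 3 values shown sit, and neither can be placed more closely. The next compound, compound 4 `Nc1nc(SC2CCCC2)c2ncn(/C=C3/CC3(CO)CO)c2n1` carries cyclopentylsulfanyl in place of propoxy on an aromatic carbon with the rest of the structure unchanged.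

Among the measured compounds shown here, the only measured step that bears on this change is a step that the two limits leave unreadable from compound 2 to compound 3 and it offers no size to carry over. Compound 1 has no reported result, so it gives no guide either. For the measured compounds named here, the expectation therefore rests on compound 3 at > 20000 nM as a limit, with no measured step pointing away from it. Any real change in this assay is expected to lean towards less compound being tolerated, though its size cannot be drawn from the data. The estimated outcome is a number no higher from compound 3 to compound 4 (the limit leaves the size open) as the expected step. Compound 4 is expected at 20000 nM with an estimated range from 6000 nM to 40000 nM and an outcome that is only a limit remains likely.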

Compound 4, half-maximal cytotoxic concentration: > 20000 nM
Compound 4 gave a limit, no number (the forecaster's own chance of this, stated with the estimate: 60%); the middle value sits exactly at the limit.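

No step to compound 4 can be read from compound 2 or compound 3, since all three compounds stand at the same limit and not at a number: the limit of > 20000 nM in this assay, at which 3 of the 4 values shown sit.

The compounds shown leave open whether ethoxy, propoxy and cyclopentylsulfanyl differ at all in this assay, and how much of any of these three compounds is tolerated.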